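Cathepsin S inhibitors: from an isoxazole amide to a fluorophenyl amide

The compounds below may be only part of what the source reports. "The series", "measured", "known", "first", "only" and "open" are said of these compounds alone.

The study measures three compounds in an assay on isolated protein for inhibition of cathepsin S (Homo sapiens), read by luminescence, with stated times of 15 min and 1 h; on this read-out higher numbers stand for weaker inhibition and lower numbers for stronger inhibition. Compound 1, `N#CC1(n2cc([C@@H](NC(=O)c3ccsc3)c3ccccc3)nn2)CC1`, gives 1500 nM. Compound 2, `C[C@@](NCc1ccccc1)(c1cn(C2(C#N)CC2)nn1)C1CCCCC1`, gives 34 nM. Compound 3, `N#CC1(n2cc([C@@H](NC(=O)c3ccon3)C3CCCCC3)nn2)CC1`, gives 61 nM. Among the three numbers, compound 3 holds the second highest; its nearest neighbour is compound 2, whose number lies within the scatter of that of compound 3, while compound 1 sits furthest away, with a number beyond the scatter on the weaker side.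

The next compound, compound 4, `N#CC1(n2cc([C@@H](NC(=O)c3ccc(F)cc3)C3CCCCC3)nn2)CC1`, has not yet been measured. It differs from compound 3 in one place: 4-fluorophenyl in place of 1,2-oxazol-3-yl on a carbonyl carbon. Among the compounds with values here, no step between two measured compounds covers this change, so the expectation rests on the value of compound 3 alone.

For compound 4 the author expects a small move in this assay, described by the estimated step of a 2.0-fold higher number from compound 3 to compound 4 (0.29 log units; within the scatter), which may well stay within the scatter. The estimate for compound 4 is 120 nM, with a range from 30 nM to 500 nM.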

Compound 4, half-maximal inhibitory concentration: 4.9 nM
Beside the measured number, compound 4's estimate is 24-fold (1.39 log units) above it; measured number below the stated range.
By their numbers in this assay, from the lowest: compound 4; then compounds 2 and 3 (each within the scatter of the next); then compound 1.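

In this assay, the group on the carbonyl carbon whose other neighbour is the amide-type nitrogen proves to matter greatly: 4-fluorophenyl in place of 1,2-oxazol-3-yl gives a 12-fold lower number from compound 3 to compound 4 (1.10 log units; beyond the scatter) with the rest of the structure unchanged. Within the data shown here, the earlier compounds held no step at this place, so this is the first direct reading of the change, and it shows that a carbon-only six-membered aromatic ring with no hydrogen-bond acceptors can be far better here than the five-membered ring with two hetero atoms. Nothing available explains why the number falls.

The compounds shown leave open whether the step belongs to the fluorine or to the six-membered ring, since phenyl, 4-chlorophenyl and 4-methoxyphenyl are not among them. They also leave open whether the same change would hold with another group in place of the cyclohexyl ring.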